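The source may report more compounds than this note shows. Statements on the series, on what has been measured and on what is new or still open speak of the compounds shown alone.

Compound 1, `O=C(Nc1ccc(S(=O)(=O)N2CCOCC2)cc1)c1ccccc1`, in an ADME assay on IMR-90 cells (Homo sapiens) for cytotoxicity, read by CellTiter-Blue, with a stated time of 46 h (a higher number here means that more compound is needed for the effect, a lower number that less compound is needed), gives only a limit of the assay, > 25000 nM. Compound 2, `O=C(Nc1ccc(S(=O)(=O)N2CCOCC2)cc1)c1ccc([N+](=O)[O-])cc1`, in this assay likewise gives a limit, > 25000 nM. Compound 3, `CC1(C)CCN(S(=O)(=O)c2cccc(NC(=O)c3ccc([N+](=O)[O-])o3)c2)CC1`, in this assay also gives a limit, > 25000 nM.

Compound 4, `CC1(C)CCN(S(=O)(=O)c2cccc(NC(=O)c3ccco3)c2)CC1`, has not yet been measured. It differs from compound 3 by hydrogen in place of nitro on an aromatic carbon. The same kind of change is seen from compound 2 to compound 1, (hydrogen in place of nitro on an aromatic carbon), where the place is a six-membered aromatic ring of carbon only, para to a large group, rather than a five-membered aromatic ring with one oxygen; there the step was a step that the two limits leave unreadable from compound 2 to compound 1. The difference between the two cores is not broken down here. All three values sit at the limit of > 25000 nM in this assay, at which 3 of the 3 values shown sit, so compound 4 is also expected to show a step that the limit leaves unreadable from compound 3 to compound 4, and its expected value is 40000 nM.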

Compound 4, half-maximal effective concentration: > 25000 nM
Compound 4 was reported as a limit; the forecaster's own chance of this, stated with the estimate: 85%; the middle value does not contradict the limit.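

Compound 3 and compound 4 both give only a limit, so no step can be read between them: the limit of > 25000 nM in this assay, at which 4 of the 4 values shown sit.

In this assay, the compounds shown leave open what concentration any of them needs for the effect, and whether hydrogen in place of nitro changes it.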